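Propoxy in place of isobutyl: compound 2 to compound 4

This account rests on a few compounds, and the source may have more. Where it says the series, first, only, none or still open, it means among the compounds named here.

In an ADME assay on Vero cells (Chlorocebus sabaeus) for cytotoxicity, read by MTT assay, with a stated time of 72 h (on this read-out lower numbers stand for higher toxicity in this test and higher numbers for lower toxicity in this test), compound 2 (`CC(C)Cc1ccc(C(=O)/C=C/c2ccc(C(=O)O)cc2)cc1`) gives < 10 ug/mL as a limit and not a number. Compound 1 (`COC(=O)c1cc(-c2cccc(NC(=O)c3ccc(C4OC4C(=O)c4ccc(Cl)cc4)cc3)c2)on1`) gives > 20 ug/mL as a limit too. Compound 3 (`COC(=O)c1cc(-c2cccc(NC(=O)c3ccc(/C=C/C(=O)c4ccccc4OC)cc3)c2)on1`) gives > 40 ug/mL as a limit as well. Compound 2 therefore stands on a limit, as do the other two, and the series holds no exact reading so far.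

Within the data shown here, the only measured step is a step that the two limits leave unreadable from compound 1 to compound 3 and it lies on another core than the one at issue here, so it offers no size to carry over. Compound 4 (`CCCOc1ccc(C(=O)/C=C/c2ccc(C(=O)O)cc2)cc1`) keeps the core of compound 2 and changes one group: propoxy in place of isobutyl on an aromatic carbon with propoxy in place of isobutyl on an aromatic carbon, para to a large group. Among the measured compounds shown here, no measured step covers this exchange. The expectation rests on compound 2 alone, with < 10 ug/mL as its limit. The estimated change is a step that the limit leaves unreadable from compound 2 to compound 4 in this assay and no step beyond the scatter is expected in either direction. For compound 4 the expected half-maximal cytotoxic concentration is 7 ug/mL with an estimated range from 2.5 ug/mL to 18 ug/mL in this series.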

Compound 4, half-maximal cytotoxic concentration: < 10 ug/mL
Compound 4 was reported as a limit; the forecaster's own chance of this, stated with the estimate: 45%; the middle value lies beyond the limit too.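

Among these compounds, compound 2 and compound 4 are both reported only as limits in this assay, so no step between them can be read. The compounds shown leave open the exact half-maximal cytotoxic concentration of either compound, and whether propoxy in place of isobutyl on an aromatic carbon shifts that read-out at all.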